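Oxazoline in place of thiazoline on the pyrazoline sulfone

The source may hold more compounds than are shown below. What is called first, only, known or untested is meant among the compounds shown, and "the series" means these compounds.

Compound 1 `COc1ccc(-c2noc(-c3ccc(C)cc3)c2S(=O)(=O)CC2=NCCO2)cc1`: 68.8%
Compound 2 `O=S(=O)(CC1=NCCS1)C1C(c2ccccc2)=NN(c2ccccc2)C1c1ccccc1`: "not active" (no number reported)
Compound 3 `O=S(=O)(CC1=NCCO1)c1c(-c2ccccc2)nn(-c2ccccc2)c1-c1ccccc1`: 54.5%

In a functional assay, read by Griess assay, with a stated time of 150 min, tested at 50 ug/mL (a higher number here means a stronger effect of the compound at the concentration tested, a lower number a weaker effect), compound 1 gives 68.8% and compound 3 gives 54.5%. Going by the values given here, compound 2 is reported in this assay only as "not active" (no number reported), without a number, so it stands apart from the two measured values and no step between measured compounds is available. Compound 4 `O=S(=O)(CC1=NCCO1)C1C(c2ccccc2)=NN(c2ccccc2)C1c1ccccc1` differs from compound 2 by a group of 5 heavy atoms (3 carbon, 1 nitrogen, 1 oxygen; one five-membered non-aromatic ring with 2 hetero atoms) in place of a group of 5 heavy atoms (3 carbon, 1 nitrogen, 1 sulfur; one five-membered non-aromatic ring with 2 hetero atoms), on a saturated chain carbon bound to a sulfonyl sulfur. Compound 3 carries the same entering group on an aromatic core and is active, so a rise of uncertain size beyond the scatter is expected in this assay, though the absence of a number for compound 2 leaves the starting point open. For compound 4 the expected value in this assay is 30%, within 0% to 60%.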

Compound 4, a percentage reported as activity, at one concentration (the size of the read-out at that concentration, not a potency): 46.7%
The estimate for compound 4 lay 16.7 percentage points below the measured number, and the stated range covers the measured number.
By their numbers in this assay, from the lowest: compounds 4 and 3 (each within the scatter of the next); then compound 1.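

No step can be read from compound 2 to compound 4, as compound 2 has no number. The compounds shown leave open how large the effect of this ring exchange is. Nothing here offers an explanation for the result.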